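This account rests on a few compounds, and the source may have more. Where it says the series, first, only, none or still open, it means among the compounds named here.

Compound 1 `COc1cc(-n2ncnc2-c2ccc(C)cc2)cc(OC)c1OC` gives 540 nM in a functional assay on MCF7 cells (Homo sapiens) for antiproliferative activity, read by MTT assay, with a stated time of 72 h; a lower number here means a stronger inhibitor, a higher number a weaker inhibitor.
Compound 2 `COc1cc(-n2ncnc2-c2cccc(F)c2)cc(OC)c1OC` gives > 10000 nM in this assay, a limit of the assay and not a number.
Compound 3 `COc1cc(-n2ncnc2-c2ccc(Cl)c(Cl)c2)cc(OC)c1OC` gives > 10000 nM in this assay, again a limit and not a number.

Compound 3 thus stands at the edge of what this assay reports, a position it shares with one other compound (the limit of > 10000 nM in this assay, at which 2 of the 3 values shown sit). Compound 4 `COc1cc(-n2ncnc2-c2ccc(SC)cc2)cc(OC)c1OC` carries 4-(methylsulfanyl)phenyl in place of 3,4-dichlorophenyl on an aromatic carbon. The step of an at least 18-fold higher number from compound 1 to compound 3 (1.26 log units; beyond the scatter), which introduced the same 3,4-dichlorophenyl, bears on this change; the step that the two limits leave unreadable from compound 2 to compound 3 cannot be read. For compound 4 the step of an at least 6.6-fold lower number from compound 3 to compound 4 (0.82 log units; beyond the scatter) is expected, a large drop, as compound 1 with 540 nM shows a singly substituted phenyl giving a real number. Compound 4 is accordingly estimated at 1500 nM, between 300 nM and 10000 nM.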

Compound 4, half-maximal inhibitory concentration: 390 nM
Estimate against measurement, compound 4: 3.8-fold (0.59 log units) above; measured number inside the range.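

There is an at least 25-fold lower number from compound 3 to compound 4 (1.40 log units; beyond the scatter) and an at least 25-fold lower number from compound 2 to compound 4 (1.40 log units; beyond the scatter) at this position, so a second group, 4-(methylsulfanyl)phenyl, gives a real number where 3-fluorophenyl and 3,4-dichlorophenyl do not. There is also a 1.4-fold lower number from compound 1 to compound 4 (0.14 log units; within the scatter) so methylsulfanyl in place of methyl makes no change beyond the scatter, and compound 1 no longer stands alone. Compound 2 and compound 3 remain limits and not numbers: the limit of > 10000 nM in this assay, at which 2 of the 4 values shown sit.

Still open, from the compounds shown here alone, is whether a single chlorine in place of the methylsulfanyl would give a real number. Also open, going by these compounds, is what an amine or a longer chain such as ethylsulfanyl would give there.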